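The source may report more compounds than this note shows. Statements on the series, on what has been measured and on what is new or still open speak of the compounds shown alone.

Compound 3 `COc1ccc(-c2cc3ccccc3nc2/C=C/C(=O)c2ccc(N)cc2)cc1` gives 7510 nM in a functional assay on MDA-MB-231 cells (Homo sapiens) for antiproliferative activity, read by XTT assay, with a stated time of 72 h (a lower number here means a stronger inhibitor, a higher number a weaker inhibitor), the second highest of the three numbers. Compound 2 `COc1ccc(C(=O)/C=C/c2nc3ccccc3cc2-c2ccc(OC)cc2)cc1` gives 7540 nM, and the two values lie within the scatter of each other; compound 1 `COc1ccc(-c2cc3ccccc3nc2/C=C/C(=O)c2ccccc2)cc1`, which carries only hydrogen at the varied position of the benzoyl group, gives 860 nM, so that an 8.7-fold higher number from compound 1 to compound 3 (0.94 log units; beyond the scatter) and an 8.8-fold higher number from compound 1 to compound 2 (0.94 log units; beyond the scatter) are both modest but beyond the scatter. Compound 4 `COc1ccc(-c2cc3ccccc3nc2/C=C/C(=O)c2ccccn2)cc1` differs from compound 3 by pyridin-2-yl in place of 4-aminophenyl on a carbonyl carbon. Loss of the amino group undoes the change behind an 8.7-fold higher number from compound 1 to compound 3 (0.94 log units; beyond the scatter), which points to a lower number; the ring nitrogen that enters has no parallel among the measured compounds, so its contribution cannot be read from them. The expected step is a 3.8-fold lower number from compound 3 to compound 4 (0.57 log units; beyond the scatter). Compound 4 is therefore estimated at 2000 nM, with a range from 600 nM to 8000 nM.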

Compound 4, half-maximal inhibitory concentration: 740 nM
Estimate against measurement, compound 4: 2.7-fold (0.43 log units) above; the range from low to high includes it.
By their numbers in this assay, from the lowest: compounds 4 and 1 (each within the scatter of the next); then compounds 3 and 2 (each within the scatter of the next).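

In this assay the ring nitrogen of pyridin-2-yl costs nothing measurable against plain phenyl on this carbonyl carbon, with a 1.2-fold lower number from compound 1 to compound 4 (0.07 log units; within the scatter) as the step. Set against the para-free substituted rings, the same group gives a 10-fold lower number from compound 3 to compound 4 (1.01 log units; beyond the scatter) and also a 10-fold lower number from compound 2 to compound 4 (1.01 log units; beyond the scatter) so the position accepts an unsubstituted phenyl or pyridin-2-yl ring, while both 4-aminophenyl and 4-methoxyphenyl stand apart from these two.

Nothing available explains why these rings differ. Going by these compounds, whether a hydroxy or chloro group on the phenyl ring, or a thiophene ring in its place, would fall with compound 4 or with compound 3 stays open.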